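This account rests on a few compounds, and the source may have more. Where it says the series, first, only, none or still open, it means among the compounds named here.

Working notes on the series. In a functional assay for inhibition, with Homo sapiens as the target (a lower number here means a stronger inhibitor, a higher number a weaker inhibitor), compound 3 `COc1cc(OC)c(C(=O)/C=C/c2ccc([N+](=O)[O-])cc2)c(OC)c1` gives 407 nM, the lowest number of the three measured. Compound 1 `COc1cc(OC)c(C(=O)/C=C/c2ccc(Cl)cc2)c(OC)c1` gives 970 nM, and compound 2 `COc1cc(OC)c(C(=O)/C=C/c2c(Cl)cccc2Cl)c(OC)c1` gives 1090 nM. Compound 4 `COc1cc(OC)c(C(=O)/C=C/c2ccc(C(=O)O)cc2)c(OC)c1` has carboxy in place of nitro on an aromatic carbon, para to a large group: carboxy in place of nitro on an aromatic carbon. For the measured compounds named here, no measured compound carries carboxy. Nitro in place of chloro gave a 2.4-fold lower number from compound 1 to compound 3 (0.38 log units; beyond the scatter), the only measured change of a group at this place and a modest one. 2,6-Dichlorophenyl in place of 4-chlorophenyl gave a 1.1-fold higher number from compound 1 to compound 2 (0.05 log units; within the scatter), which offers little guidance. On the size of the nitro step, a modest move to a higher number is expected, namely a 2.2-fold higher number from compound 3 to compound 4 (0.34 log units; beyond the scatter). Compound 4 is estimated at 900 nM, with an expected range of 300 nM to 3000 nM.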

Compound 4, half-maximal inhibitory concentration: 6230 nM
For compound 4 the middle estimate is 6.9-fold (0.84 log units) below the measured one, and the stated range ends below it.
By their numbers in this assay, from the lowest: compound 3; then compounds 1 and 2 (each within the scatter of the next); then compound 4.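

For the compounds shown here, at this place, on an aromatic carbon para to a large group, the choice of group can move the number much further than the earlier compounds showed: in this assay, carboxy in place of nitro gives a 15-fold higher number from compound 3 to compound 4 (1.18 log units; beyond the scatter). Carboxy in place of chloro gives a 6.4-fold higher number from compound 1 to compound 4 (0.81 log units; beyond the scatter), so carboxy gives the highest number of the three groups compared here. Nothing at hand explains the size of these steps. From the compounds shown here alone, whether a methyl ester or a primary amide at this place stays near compound 4 or comes closer to compound 3 remains open.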